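A few compounds are considered here, and "the series" means these few. Any claim that something is new, unique, unknown or untested is made for them only; others in the source may bear on it.

Compound 2 `CC1(C)C=C(n2ccccc2=O)c2cc(S(=O)(=O)NCc3ccccc3)ccc2O1` carries a benzyl group on its sulfonamide nitrogen. For the measured compounds named here, in a functional assay with Rattus norvegicus as the target (a higher number here means that more compound is needed for the effect, a lower number that less compound is needed), compound 2 gives 1320 nM, the higher of the two numbers measured so far. Going by the values given here, its only neighbour, compound 1 `CNS(=O)(=O)c1ccc2c(c1)C(n1ccccc1=O)=CC(C)(C)O2`, gives 138 nM in this assay, and the one step measured, a 9.6-fold higher number from compound 1 to compound 2 (0.98 log units; beyond the scatter), came with phenyl in place of hydrogen on the chain carbon bound to that nitrogen. Compound 3 `CC1(C)C=C(n2ccccc2=O)c2cc(S(=O)(=O)Nc3ccc([N+](=O)[O-])cc3)ccc2O1` differs from compound 2 by 4-nitrophenyl in place of benzyl on a sulfonamide nitrogen. Among the compounds with values here, no measured step touches the same change: the step from compound 1 to compound 2 shows only that adding an aromatic ring at this position raised the number, and it says nothing about swapping one aromatic group for another directly on the nitrogen. The expectation is therefore a number close to that of compound 2, with wide uncertainty in both directions. Compound 3 is expected to give 1500 nM, between 400 nM and 6000 nM, which would mean a step of a 1.1-fold higher number from compound 2 to compound 3 (0.06 log units; within the scatter).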

Compound 3, half-maximal effective concentration: 10200 nM
Estimate against measurement, compound 3: 6.8-fold (0.83 log units) below, outside the stated range (above it).
By their numbers in this assay, from the lowest: compound 1; then compound 2; then compound 3.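

Swapping benzyl for 4-nitrophenyl on the sulfonamide nitrogen gave a 7.7-fold higher number from compound 2 to compound 3 (0.89 log units; beyond the scatter) in this assay, although both groups hold one six-membered aromatic ring of carbon only. Having such a ring on this side of the nitrogen is therefore not all that sets the number: what the ring carries, how it is attached, or both also count. Measured from the methyl group, the change is a 74-fold higher number from compound 1 to compound 3 (1.87 log units; beyond the scatter) and is the largest step among these compounds. Nothing shown here gives a measured reason for these steps.

The change attaches the ring directly to the nitrogen and adds the nitro group in one move, so the two effects cannot be told apart. Going by these compounds, a plain phenyl group on that nitrogen could separate them, and how a longer chain such as propyl would behave there also remains open.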